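The source may hold more compounds than are shown below. What is called first, only, known or untested is meant among the compounds shown, and "the series" means these compounds.

Of the compounds shown here, two have been measured in an assay for inhibition of Nicotinamide phosphoribosyltransferase (Homo sapiens), read by mass spectrometry, with stated times of 15 min and 30 min; on this read-out higher numbers stand for weaker inhibition and lower numbers for stronger inhibition. Compound 1 `O=C(NCc1ccc(S(=O)(=O)c2cccc(F)c2)cc1)c1cc2cnccc2[nH]1` gives 5 nM, the lowest of the two numbers. Compound 2 `O=C(NCc1ccc(S(=O)(=O)N2CCCCC2)cc1)c1ccc2nc[nH]c2c1` gives 310 nM, a far higher number, but the two structures differ in several places at once, so the gap says nothing about any single change. Compound 3 `O=C(NCc1ccc(S(=O)(=O)c2ccc(F)c(F)c2)cc1)c1cc2cnccc2[nH]1` differs from compound 1 in one place only: fluoro in place of hydrogen on an aromatic carbon. Within the data shown here, no measured pair shows this change, so there is nothing to lean on; one more fluoro on the same ring is expected to move the number little. Compound 3 is therefore expected near 5 nM, within 2 nM to 15 nM. The step of no change at the digits printed from compound 1 to compound 3 (within the scatter) is expected to stay within the usual scatter.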

Compound 3, half-maximal inhibitory concentration: 10 nM
Compound 3: middle estimate off by 2.0-fold (0.30 log units), on the low side; the measured number falls inside the stated range.
By their numbers in this assay, from the lowest: compounds 1 and 3 (each within the scatter of the next); then compound 2.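

The step from 3-fluorophenyl to 3,4-difluorophenyl is a 2.0-fold higher number from compound 1 to compound 3 (0.30 log units; within the scatter) in this assay, so compound 1 and compound 3 cannot be told apart on this read-out. Among these compounds, this is the first comparison here that isolates a single change, and it shows that a fluoro can sit on this aromatic carbon, para to a large group, without a step beyond the scatter. Nothing measured here gives a reason for this result. Still open, from the compounds shown here alone, is whether a methoxy group or an amine on the same carbon would be accommodated equally well. Also open, going by these compounds, is how a plain phenyl ring, carrying no fluoro, would compare.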